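Cytotoxicity notes on acetylated glycoside enones

This account rests on a few compounds, and the source may have more. Where it says the series, first, only, none or still open, it means among the compounds named here.

Compound 1 `COc1ccccc1/C=C/C(=O)C[C@@H]1O[C@H](COC(C)=O)[C@@H](OC(C)=O)[C@H](OC(C)=O)[C@H]1OC(C)=O` carries a 2-methoxyphenyl group on the enone chain of the shared core. In an ADME assay on cells (Epithelial cell, Homo sapiens) for cytotoxicity, read by MTT assay, with a stated time of 24 h (on this read-out higher numbers stand for lower toxicity in this test and lower numbers for higher toxicity in this test), compound 1 has no reported result, its entry reading "not determined" (no result reported). Compound 2 `CC(=O)OC[C@H]1O[C@@H](CC(=O)/C=C/c2cccc3ccccc23)[C@H](OC(C)=O)[C@@H](OC(C)=O)[C@@H]1OC(C)=O` likewise has no reported result in this assay, its entry reading "not determined" (no result reported). For the measured compounds named here, the only number in hand comes from compound 3 `CC(=O)OC[C@H]1O[C@@H](CC(=O)/C=C/c2ccc(Cl)c(Cl)c2)[C@H](OC(C)=O)[C@@H](OC(C)=O)[C@@H]1OC(C)=O`, which in this assay gives 25.8 nM. Compound 1 therefore stands nowhere on the numbers shown; it cannot be placed above or below compound 3.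

Compound 4 `CC(=O)OC[C@H]1O[C@@H](CC(=O)/C=C/c2ccc(C(F)(F)F)cc2)[C@H](OC(C)=O)[C@@H](OC(C)=O)[C@@H]1OC(C)=O` is the next entry to be measured. Its difference from compound 1 is 4-(trifluoromethyl)phenyl in place of 2-methoxyphenyl on a double-bonded chain carbon bound to a double-bonded chain carbon. Going by the values given here, no step between measured compounds is available to calibrate this change, so no direction can be read from the series itself. Among the compounds with values here, with compound 1 unmeasured, the expected size of the step in this assay from compound 1 to compound 4 cannot be stated; the only anchor is compound 3 at 25.8 nM.

Resting on that single point, compound 4 is expected to give about 30 nM in this assay, with a range estimated from 8 nM to 120 nM.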

Compound 4, half-maximal cytotoxic concentration: 103 nM
Estimate against measurement, compound 4: 3.4-fold (0.54 log units) below; the range from low to high includes it.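

In this assay the step of a 4.0-fold higher number from compound 3 to compound 4 (0.60 log units; beyond the scatter) comes with 4-(trifluoromethyl)phenyl in place of 3,4-dichlorophenyl on a double-bonded chain carbon bound to a double-bonded chain carbon. With the rest of the shared core unchanged, this shows that the aryl group at this place can move the read-out beyond the usual scatter, here towards lower toxicity in this test. No measured finding on hand bears on the reason for this step.

Going by these compounds, with no result reported for compound 1 or compound 2, the standing of the 2-methoxyphenyl group against these two aryl groups remains open. Also open, on these data alone, is how an amine or a carboxylic acid on the aryl ring at this place would read in this assay and whether a single step of this kind holds beyond this pair.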